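The source may report more compounds than this note shows. Statements on the series, on what has been measured and on what is new or still open speak of the compounds shown alone.

Values in an ADME assay on microsomes from liver (Homo sapiens) for metabolic stability (a higher number here means that the compound lasts longer, a lower number that the compound disappears faster), so far:

- Compound 1 `CC(C)[C@@H](c1ccc(-c2ccc3cccc(F)c3c2)[nH]c1=O)[C@@H]1OC(=O)NC1=O` gives > 3 h (a limit)
- Compound 2 `CCC(CC)C(/C=C1\OC(=O)NC1=O)c1ccc(-c2ccc3cccc(F)c3c2)[nH]c1=O` gives > 3 h (a limit)
- Compound 3 `O=C1NC(=O)/C(=C/C2(c3ccc(-c4ccc5cccc(F)c5c4)[nH]c3=O)CC2)O1` gives 2.48 h (a measured number)

The main constraint on the series is the limit of > 3 h in this assay, at which 2 of the 3 values shown sit (compound 1 and compound 2). Compound 2 stands at > 3 h (a limit of the assay, not a number), so its true half-life is not known.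

Compound 4 `O=C1NC(=O)/C(=C/C(Cc2ccccc2)c2ccc(-c3ccc4cccc(F)c4c3)[nH]c2=O)O1` is the next to be read. It carries benzyl in place of pentan-3-yl on a saturated chain carbon bound to an aromatic carbon and a double-bonded chain carbon.

Among the compounds with values here, no measured pair isolates this change. Within the data shown here, the only anchor for a number is compound 3 at 2.48 h in this assay as a neighbouring value. The expected step is an at least 1.2-fold lower number from compound 2 to compound 4 (0.07 log units; that floor lies within the scatter) (small, downward, and not beyond the usual scatter). A further limit reading would not be surprising. For compound 4 the estimated half-life is 2.5 h (expected range 1.2 h to 4.5 h).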

Compound 4, half-life: 1.3 h
Beside the measured number, compound 4's estimate is 1.9-fold (0.28 log units) above it; the measured number falls inside the stated range.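

In this assay, within the data shown here, the substituent on the saturated chain carbon bound to an aromatic carbon and a double-bonded chain carbon now gives a readable step for the first time: benzyl in place of pentan-3-yl gives an at least 2.3-fold lower number from compound 2 to compound 4 (0.36 log units; beyond the scatter). Among these compounds, the earlier compounds offered no step at this position, so this change is the first sign that the group held there can matter for half-life. The step is only a floor because compound 2 holds a limit and not a number: the limit of > 3 h in this assay, at which 2 of the 4 values shown sit.

Going by these compounds, what stays open is whether the step follows the aromatic ring of benzyl or simply the replacement of the branched pentan-3-yl chain. Cyclohexylmethyl or pyridin-3-ylmethyl at this position would help separate these readings.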